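The compounds below may be only part of what the source reports. "The series", "measured", "known", "first", "only" and "open" are said of these compounds alone.

Measured so far in an assay on isolated protein for inhibition of Indoleamine 2,3-dioxygenase 1 (Homo sapiens), with a stated time of 1 h; a lower number here means a stronger inhibitor, a higher number a weaker inhibitor:
compound 1 `c1ccc(Cn2cncc2-c2cc3ccccc3[nH]2)cc1`: 34800 nM
compound 2 `Cc1ccc(Cn2cncc2-c2cc3cc(Br)ccc3[nH]2)cc1`: 21600 nM
compound 3 `Brc1ccc2[nH]c(-c3cncn3CC3CCCCN3)cc2c1`: a limit, > 100000 nM

Compound 2 and compound 1 sit within the scatter of each other. The value of compound 3 is only a limit (the limit of > 100000 nM in this assay, at which 1 of the 3 values shown sits), not a number.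

Compound 4 `Oc1ccccc1Cn1cncc1-c1cc2cc(Br)ccc2[nH]1` differs from compound 2 by 2-hydroxyphenyl in place of 4-methylphenyl on a saturated chain carbon bound to an aromatic nitrogen. Among the measured compounds shown here, the only measured step at that place is an at least 4.6-fold higher number from compound 2 to compound 3 (0.66 log units; beyond the scatter), where an aromatic ring gave way to piperidin-2-yl; compound 4 keeps an aromatic ring there, so that step is a weak guide. No step beyond the scatter is expected, with the upper side left open. Compound 4 is expected at 22000 nM (range 7000 nM to 70000 nM). The expected step is a 1.0-fold higher number from compound 2 to compound 4 (0.01 log units; within the scatter).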

Compound 4, half-maximal inhibitory concentration: 6400 nM
Beside the measured number, compound 4's estimate is 3.4-fold (0.54 log units) above it; measured number below the stated range.
By their numbers in this assay, from the lowest: compound 4; then compounds 2 and 1 (each within the scatter of the next). At a limit, above all of these: compound 3.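

At the place on a saturated chain carbon bound to an aromatic nitrogen, exchanging one aromatic ring for another also moves the number: 2-hydroxyphenyl in place of 4-methylphenyl gives a 3.4-fold lower number from compound 2 to compound 4 (0.53 log units; beyond the scatter) in this assay and shows that this position responds even with an aromatic ring kept. The value of compound 3 is a limit, not a number. Against that limit, 2-hydroxyphenyl in place of piperidin-2-yl reads as an at least 15-fold lower number from compound 3 to compound 4 (1.19 log units; beyond the scatter) in this assay and keeps the aromatic ring at the lower end.

On these data alone, the methyl leaves in the same change, so the share of the hydroxyl in the step stays open. A 2-methoxyphenyl or 2-aminophenyl group at this place would test it.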